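This account rests on a few compounds, and the source may have more. Where it says the series, first, only, none or still open, it means among the compounds named here.

Measured compounds in a functional assay on Hep 3B2 cells (Homo sapiens) for inhibition, read by sulforhodamine B assay, with a stated time of 72 h; a higher number here means a weaker inhibitor, a lower number a stronger inhibitor:
- compound 1 `COc1ccc(C2=Nn3c(nnc3C(C)c3ccc(-c4ccccc4)c(F)c3)SC2)cc1` — 3500 nM
- compound 2 `CC(c1ccc(-c2ccccc2)c(F)c1)c1nnc2n1N=C(c1ccc(Cl)cc1)CS2` — 3800 nM
- compound 3 `CC(c1ccc(-c2ccccc2)c(F)c1)c1nnc2n1N=C(c1ccc(Br)cc1)CS2` — 1500 nM

Compound 3 gives the lowest number of the three in this assay, and its steps to both others lie beyond the scatter: a 2.3-fold lower number from compound 1 to compound 3 (0.37 log units; beyond the scatter) and a 2.5-fold lower number from compound 2 to compound 3 (0.40 log units; beyond the scatter). Compounds 1 and 2 are not separated from each other: a 1.1-fold higher number from compound 1 to compound 2 (0.04 log units; within the scatter).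

Compound 4 `CC(c1ccc(-c2ccccc2)c(F)c1)c1nnc2n1N=C(c1ccc([N+](=O)[O-])cc1)CS2` is not yet measured. The change from compound 3 is nitro in place of bromo on an aromatic carbon. All three measured steps bear on it, since each swaps the group at the same aromatic carbon: methoxy, chloro and bromo all land within a modest span, with bromo the lowest number. Nitro has no measured counterpart in the series, so nothing shows whether it sits with bromo or with the other two. The safer expectation is that compound 4 returns toward the numbers of compounds 1 and 2, a modest step upward at most, or no step beyond the scatter.

For compound 4 in this assay the estimate is 3000 nM, with a range of 1000 nM to 9000 nM, which means an expected step of a 2.0-fold higher number from compound 3 to compound 4 (0.30 log units; within the scatter).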

Compound 4, half-maximal inhibitory concentration: 2900 nM
For compound 4 the middle estimate is 1.0-fold (0.01 log units) above the measured one, and the stated range covers the measured number.
By their numbers in this assay, from the lowest: compounds 3, 4, 1 and 2 (each within the scatter of the next, the first and the last beyond it).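

In this assay, nitro at this aromatic carbon, para to a large group, cannot be told apart from any of the three groups tried there before it, as the steps show: (a 1.9-fold higher number from compound 3 to compound 4 (0.29 log units; within the scatter)), (a 1.3-fold lower number from compound 2 to compound 4 (0.12 log units; within the scatter)) and (a 1.2-fold lower number from compound 1 to compound 4 (0.08 log units; within the scatter)). Compound 3 remains separated from compounds 1 and 2 but not from compound 4, so bromo no longer stands apart from every other group at this carbon, and a swap that brings in three heavy atoms and two hydrogen-bond acceptors for a single bromine gives no step beyond the scatter. Nothing available here accounts for these numbers.

Still open, from the compounds shown here alone, is whether any group at this carbon can move the number well outside the narrow span of these four compounds, for instance an amine, a carboxylic acid or a longer chain such as butyl. The compounds shown also vary only this one place, so they say nothing about how the same groups would behave elsewhere on that ring or with changes to the rest of the shared core.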